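The source may hold more compounds than are shown below. What is called first, only, known or untested is meant among the compounds shown, and "the series" means these compounds.

Measured values in an ADME assay on microsomes from liver (Homo sapiens) for metabolic stability, read by LC-MS, using NADPH, with stated times of 5 min and 30 min, tested at 1 uM (on this read-out lower numbers stand for slow clearance and higher numbers for fast clearance), for three compounds:
- compound 1 `O=C(Nc1ccccc1)c1cnc(NCc2c(F)ccc3c2CCO3)n2cnnc12` at 14 mL.min-1.g-1
- compound 2 `CN(c1ccn(C)n1)c1cnc(NCc2c(F)ccc3c2CCO3)n2cnnc12` at 11 mL.min-1.g-1
- compound 3 `O=C(Nc1cnc(NCc2c(F)ccc3c2CCO3)n2cnnc12)c1cccnc1` at < 3 mL.min-1.g-1 (a limit, not a number)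

Compound 3 is the lowest of the three on the numbers shown: it sits at the limit of < 3 mL.min-1.g-1 in this assay, at which 1 of the 3 values shown sits, and is reported only as a limit.

The change to compound 4 `O=C1CC2(CC2)CN1c1cnc(NCc2c(F)ccc3c2CCO3)n2cnnc12` is a group of 8 heavy atoms (6 carbon, 1 nitrogen, 1 oxygen; one three-membered non-aromatic ring of carbon only, one five-membered non-aromatic ring with 1 hetero atom) in place of a group of 9 heavy atoms (6 carbon, 2 nitrogen, 1 oxygen; one six-membered aromatic ring with 1 hetero atom), on an aromatic carbon and stands on an aromatic carbon of the shared core. Three measured steps at that place bear on it: an at least 4.6-fold lower number from compound 1 to compound 3 (0.66 log units; beyond the scatter) and an at least 3.6-fold lower number from compound 2 to compound 3 (0.56 log units; beyond the scatter) both end at the limit, and a 1.3-fold lower number from compound 1 to compound 2 (0.10 log units; within the scatter) is small. Only compound 3 carries the ((pyridin-3-yl)carbonyl)amino group, and compound 4 loses it, so a partial return toward compound 1 at 14 mL.min-1.g-1 and compound 2 at 11 mL.min-1.g-1 is expected. A modest upward move is expected in this assay as an at least 2.3-fold higher number from compound 3 to compound 4 (0.36 log units; beyond the scatter) and a reading at the limit remains possible. Compound 4 is estimated at 7 mL.min-1.g-1 with 3 mL.min-1.g-1 to 16 mL.min-1.g-1 as the expected range.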

Compound 4, intrinsic clearance in microsomes: < 3 mL.min-1.g-1
Compound 4: no number, only a limit (the forecaster's own chance of this, stated with the estimate: 20%); at least 2.3-fold (0.36 log units) between middle value and limit.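

In this assay compound 4 reads < 3 mL.min-1.g-1, which is a limit and not a number. The group entering on this aromatic carbon of the shared core gives an at least 4.6-fold lower number from compound 1 to compound 4 (0.66 log units; beyond the scatter) and an at least 3.6-fold lower number from compound 2 to compound 4 (0.56 log units; beyond the scatter), so the low reading no longer rests on the ((pyridin-3-yl)carbonyl)amino group alone, and needs neither its six-membered aromatic ring nor a hydrogen-bond donor in the group. The step between compound 3 and compound 4 cannot be read, and neither compound can be placed above the other, as both stand at: the limit of < 3 mL.min-1.g-1 in this assay, at which 2 of the 4 values shown sit.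

As far as these compounds go, how far compound 3 and compound 4 lie under that limit stays open. Also open, from the compounds shown here alone, is what the three-membered ring contributes, which a plain pyrrolidin-2-one at the same carbon would address, while an open-chain amide would test the five-membered ring.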